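The compounds below may be only part of what the source reports. "The series", "measured", "known", "first", "only" and "open" are said of these compounds alone.

Measured compounds:
compound 1 `COc1cc2c(Oc3ccc(NC(=O)c4nnn(-c5ccccc5C)c4C)cc3F)ccnc2cc1OCCCN1CCCCC1` — 160 nM
compound 2 `COc1cc2c(Oc3ccc(NC(=O)c4nnn(-c5ccc(F)cc5)c4C(F)(F)F)cc3F)ccnc2cc1OCCCN1CCCCC1` — 40 nM
compound 3 `COc1cc2c(Oc3ccc(NC(=O)c4nnn(-c5ccccc5C)c4C)cc3F)ccnc2cc1OCCCN1CCC(C)CC1` — 120 nM

Notes on the series. In a functional assay on MKN-45 cells (Homo sapiens) for cytotoxicity, read by MTT assay, with a stated time of 72 h (a lower number here means a stronger inhibitor, a higher number a weaker inhibitor), compound 2 gives the lowest number of the three measured compounds, with both other values beyond the scatter from it. The change from compound 1 to compound 3 methyl in place of hydrogen on a saturated ring carbon gave a 1.3-fold lower number from compound 1 to compound 3 (0.12 log units; within the scatter), a step within the scatter. How the core of compound 2 differs from the core of compound 1 is not broken down here.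

Compound 4 `COc1cc2c(Oc3ccc(NC(=O)c4nnn(-c5ccc(F)cc5)c4C(F)(F)F)cc3F)ccnc2cc1OCCCN1CCC(C)CC1` is not yet measured. It carries the same change relative to compound 2 methyl in place of hydrogen on a saturated ring carbon as compound 3 carries relative to compound 1, at a place described in identical words. The expectation for compound 4 in this assay is therefore a step of similar size, a 1.1-fold lower number from compound 2 to compound 4 (0.06 log units; within the scatter), resting on a 1.3-fold lower number from compound 1 to compound 3 (0.12 log units; within the scatter) alone. Compound 4 is accordingly estimated at 35 nM, with a range from 18 nM to 70 nM.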

Compound 4, half-maximal inhibitory concentration: 70 nM
The estimate for compound 4 lay 2.0-fold (0.30 log units) below the measured number; the measured number falls inside the stated range.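

In this assay, the change from piperidin-1-yl to 4-methylpiperidin-1-yl gave a 1.8-fold higher number from compound 2 to compound 4 (0.24 log units; within the scatter), a step within the scatter. Set beside the step on the core of compound 1, the result gives no sign that the two cores respond differently: the same change on two cores in this assay, a 1.3-fold lower number (0.12 log units; within the scatter) from compound 1 to compound 3 and a 1.8-fold higher number (0.24 log units; within the scatter) from compound 2 to compound 4, 2.3-fold (0.37 log units) apart, within the scatter of two such steps. The methyl therefore carries between these two cores without a step distinguishable from the scatter, but two pairs do not show that this holds on other cores, nor do they resolve any small true effect on either core.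

Still open, on these data alone, is whether an ethyl or a hydroxyl on the same saturated ring carbon would also leave the number within the scatter. Also open, as far as these compounds go, is how morpholin-4-yl in place of piperidin-1-yl would behave on either core.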